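Adding a second ester to compound 1

This account rests on a few compounds, and the source may have more. Where it says the series, first, only, none or still open, it means among the compounds named here.

Of the compounds shown here, two have been measured in an ADME assay on a cell-free system (plasma, Rattus norvegicus) for metabolic stability, read by LC-MS, with a stated time of 60 min, at 37 degrees C, tested at 50 uM; a higher number here means that more of the compound is left, a lower number that less of the compound is left: compound 1 `CCC(CC)C(=O)OCOC(=O)C1=C(S[C@@H]2CN[C@H](C(=O)Nc3cccc(C(=O)O)c3)C2)[C@H](C)[C@@H]2[C@@H]([C@@H](C)O)C(=O)N12` gives 0%, and compound 2 `CCOC(=O)OCOC(=O)C1=C(S[C@@H]2CN[C@H](C(=O)Nc3cccc(C(=O)O)c3)C2)[C@H](C)[C@@H]2[C@@H]([C@@H](C)O)C(=O)N12` gives 0%.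

Compound 1 thus stands level with compound 2; the step of no change at the digits printed from compound 1 to compound 2 (within the scatter), ethoxy in place of pentan-3-yl on a carbonyl carbon, left the read-out unchanged. Compound 3 `CCC(CC)C(=O)OCOC(=O)C1=C(S[C@@H]2CN[C@H](C(=O)Nc3cccc(C(=O)OCOC(=O)C(CC)CC)c3)C2)[C@H](C)[C@@H]2[C@@H]([C@@H](C)O)C(=O)N12` differs from compound 1 by (((pentan-3-yl)carbonyl)oxy)methyl in place of hydrogen on an oxygen next to a carbonyl group. Among the compounds with values here, the one measured step concerns another part of the molecule and was flat, so in this assay a step of no change at the digits printed from compound 1 to compound 3 (within the scatter) with no change beyond the scatter is expected. Compound 3 is estimated at 0%, within 0% to 10%.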

Compound 3, percent of the compound remaining: 3%
Compound 3: the middle estimate sits 3 percentage points below what was measured; low and high end bracket the measured number.
By their numbers in this assay, from the lowest: compounds 1, 2 and 3 (each within the scatter of the next).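

In this assay, within the data shown here, (((pentan-3-yl)carbonyl)oxy)methyl in place of hydrogen on an oxygen next to a carbonyl group gives a number 3 percentage points higher from compound 1 to compound 3 (within the scatter), the first measured change at this position. The free carboxy group of compound 1 can therefore carry this second ester without a read-out change beyond the scatter, and all three compounds remain close to the bottom of the scale. No measured finding bears on why this is so. The compounds shown leave open whether a carboxamide or a plain methyl ester at this position would leave more compound intact.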